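The compounds below may be only part of what the source reports. "The series", "measured", "known", "first", "only" and "open" are said of these compounds alone.

Working notes on the series.

Compound 1 `CCCOc1cc(C(F)(F)F)ccc1CNC(=O)C(C)c1ccc(NS(C)(=O)=O)c(F)c1` gives 2 nM in an assay on CHO cells for antagonist activity at transient receptor potential cation channel subfamily V member 1 (Homo sapiens), read by FLIPR; a lower number here means a stronger inhibitor, a higher number a weaker inhibitor. Compound 2 `CCCCSc1cc(C(F)(F)F)ccc1CNC(=O)C(C)c1ccc(NS(C)(=O)=O)c(F)c1` gives 1.9 nM in this assay, and compound 3 `CCCCCCSc1cc(C(F)(F)F)ccc1CNC(=O)C(C)c1ccc(NS(C)(=O)=O)c(F)c1` gives 1.8 nM in this assay. Compound 3 holds the lowest of the three numbers, yet the step of a 1.1-fold lower number from compound 1 to compound 3 (0.05 log units; within the scatter) and the step of a 1.1-fold lower number from compound 2 to compound 3 (0.02 log units; within the scatter) both sit within the scatter, as does the step of a 1.1-fold lower number from compound 1 to compound 2 (0.02 log units; within the scatter), so the three compounds are indistinguishable on this assay. Exchanging propoxy for butylsulfanyl or hexylsulfanyl, and lengthening the chain by ethyl, left the number unmoved.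

Compound 4 `COc1ccc(CSc2cc(C(F)(F)F)ccc2CNC(=O)C(C)c2ccc(NS(C)(=O)=O)c(F)c2)cc1` is not yet measured. It differs from compound 3 by 4-methoxyphenyl in place of pentyl on a saturated chain carbon bound to a sulfur. The measured steps concern only chain length and the oxygen-to-sulfur exchange; none introduces an aromatic ring at this place, so they bear on it only indirectly, showing tolerance of varied groups on this side of the core. On that basis a step of a 1.7-fold higher number from compound 3 to compound 4 (0.22 log units; within the scatter) is expected for compound 4, which is no step beyond the scatter. Compound 4 is estimated at 3 nM in this assay, with a range of 1 nM to 10 nM.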

Compound 4, inhibition constant: 2.3 nM
Compound 4: the middle estimate sits 1.3-fold (0.12 log units) above what was measured, within the range that was stated.
By their numbers in this assay, from the lowest: compounds 3, 2, 1 and 4 (each within the scatter of the next).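

4-methoxyphenyl in place of pentyl on a saturated chain carbon bound to a sulfur brings an aromatic ring and an ether oxygen to this place for the first time, and a 1.3-fold higher number from compound 3 to compound 4 (0.11 log units; within the scatter) in this assay shows that this larger group is tolerated. The same holds against the other two compounds, with a 1.2-fold higher number from compound 2 to compound 4 (0.08 log units; within the scatter) and a 1.2-fold higher number from compound 1 to compound 4 (0.06 log units; within the scatter) both showing no separation, so the tolerance seen among the chains extends to (4-methoxybenzyl)sulfanyl. No evidence on hand explains why the number stays flat across these groups.

As far as these compounds go, what an amine or a carboxylic acid in place of the 4-methoxyphenyl would do remains open. Also open, from the compounds shown here alone, is whether any group at this place can move the number beyond the scatter.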